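The compounds below may be only part of what the source reports. "The series", "measured", "known", "first", "only" and "open" are said of these compounds alone.

Measured so far in an ADME assay on microsomes from liver (Homo sapiens) for metabolic stability; a lower number here means that the compound disappears faster, a higher number that the compound lasts longer:

compound 1 `CCCNC(=O)[C@@H]1C[C@H]2CCC[C@@H](C1)[C@@H]2NC(=O)c1cc2scnc2n1Cc1ccc(OC)cc1` gives 0.743 h
compound 2 `CCCNC(=O)C1CCN(C(=O)c2cc3[nH]cnc3n2Cc2ccc(OC)cc2)CC1` gives 1.27 h
compound 3 `CCCNC(=O)[C@@H]1CCCN1C(=O)c1cc2sc(Br)cc2n1Cc1ccc(OC)cc1` gives 0.303 h

Compound 1 at 0.743 h lies within the usual scatter of compound 2 at 1.27 h and so cannot be ordered against it. Compound 3 at 0.303 h lies lower than compound 1, and that gap is beyond the scatter.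

The next compound to be measured is compound 4 `CCCNC(=O)[C@@H]1C[C@H]2CCC[C@@H](C1)[C@@H]2NC(=O)c1cc2sc(Br)nc2n1Cc1ccc(OC)cc1` which keeps the core of compound 1 and its side chains. The change is bromo in place of hydrogen on an aromatic carbon and amounts to bromo in place of hydrogen on an aromatic carbon of the five-membered aromatic ring with 1 nitrogen and 1 sulfur.

Among the compounds with values here, no measured pair isolates this change, so the size of the step is not known from the data. Compound 3 also carries a bromo and gives 0.303 h but it differs from compound 1 in several places, so it offers only a weak hint of a downward direction. The expected result is a 1.2-fold lower number from compound 1 to compound 4 (0.09 log units; within the scatter) which is a small decrease that is not expected to go beyond the scatter. In this assay the estimated value for compound 4 is 0.6 h within an expected range of 0.3 h to 1.2 h on repeat measurement.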

Compound 4, half-life: 0.867 h
Compound 4: the middle estimate sits 1.4-fold (0.16 log units) below what was measured, and the stated range covers the measured number.
By their numbers in this assay, from the lowest: compound 3; then compounds 1, 4 and 2 (each within the scatter of the next).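

Bromo in place of hydrogen on an aromatic carbon of the five-membered aromatic ring with 1 nitrogen and 1 sulfur, next to the ring nitrogen and next to the ring sulfur, gives in this assay a 1.2-fold higher number from compound 1 to compound 4 (0.07 log units; within the scatter). Within the data shown here, this is the first pair that isolates a change at this position, and it shows that adding this one heavy atom on the core of compound 1 leaves no step that can be told apart from repeat measurement, so the two compounds cannot be ordered. Nothing at hand bears on why this substitution leaves the half-life within the scatter.

Among these compounds, how a chloro, a methyl, a nitrile or an amine on this same aromatic carbon would read in this assay remains open, so the single bromo step says nothing yet about other groups at this position. Among the compounds shown here, also open is whether the same bromo step would stay within the scatter on a core other than that of compound 1, as no pair in hand tests it elsewhere.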